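Ethynyl in place of methyl: notes on compound 4

The compounds below may be only part of what the source reports. "The series", "measured", "known", "first", "only" and "open" are said of these compounds alone.

In a functional assay on HCT-116 cells (Homo sapiens) for antiproliferative activity, read by MTT assay, with a stated time of 72 h (on this read-out lower numbers stand for stronger inhibition and higher numbers for weaker inhibition), compound 1 (`O=C(CCc1cccc2c1B(O)OC2)Nc1ccccc1`) gives 350 nM, compound 2 (`O=C(CCc1cccc2c1B(O)OC2)Nc1ccc(Br)cc1`) gives 46000 nM and compound 3 (`Cc1ccc(NC(=O)CCc2cccc3c2B(O)OC3)cc1`) gives 4500 nM, the middle number of the three. Compound 4 (`C#Cc1ccc(NC(=O)CCc2cccc3c2B(O)OC3)cc1`) carries ethynyl in place of methyl on an aromatic carbon, para to a large group (ethynyl in place of methyl on an aromatic carbon). Three large steps bear on this place: a 130-fold higher number from compound 1 to compound 2 (2.12 log units; beyond the scatter), a 13-fold higher number from compound 1 to compound 3 (1.11 log units; beyond the scatter) and a 10-fold lower number from compound 2 to compound 3 (1.01 log units; beyond the scatter). Among the compounds with values here, both substituents tested there sit higher than hydrogen, and no measurement yet covers ethynyl. The expected change is a 2.7-fold higher number from compound 3 to compound 4 (0.43 log units; beyond the scatter) in this assay, a moderate move towards a higher number. For compound 4 the estimate is 12000 nM, with an expected range from 2500 nM to 45000 nM for repeated measurements.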

Compound 4, half-maximal inhibitory concentration: 45000 nM
Beside the measured number, compound 4's estimate is 3.8-fold (0.57 log units) below it; low and high end bracket the measured number.
By their numbers in this assay, from the lowest: compound 1; then compound 3; then compounds 4 and 2 (each within the scatter of the next).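

In this assay, ethynyl moves the number well away from hydrogen (a 130-fold higher number from compound 1 to compound 4 (2.11 log units; beyond the scatter)) and further still from methyl (a 10-fold higher number from compound 3 to compound 4 (1.00 log units; beyond the scatter)), while ethynyl and bromo cannot be told apart (a 1.0-fold lower number from compound 2 to compound 4 (0.01 log units; within the scatter)). All three substituents tested on this aromatic carbon now sit higher than hydrogen, and compound 1 keeps the lowest number of the four. No measured evidence accounts for this order. Open, as far as these compounds go, is whether any other group here, such as an amine, a hydroxyl or a carboxylic acid, would stay close to compound 1 or rise like the others.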